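The source may hold more compounds than are shown below. What is called first, only, known or untested is meant among the compounds shown, and "the series" means these compounds.

Compound 1 `O=C(Nc1cccc(C(F)(F)F)c1)c1nccc2ccccc12`: in a functional assay on NUGC-3 cells (Homo sapiens) for inhibition, read by sulforhodamine B assay, with a stated time of 48 h (a higher number here means a weaker inhibitor of growth, a lower number a stronger inhibitor of growth), compound 1 gives > 10000 nM, a limit of the assay.
Compound 2 `O=C(Nc1cccc(Cl)c1)c1nccc2ccccc12`: in this assay compound 2 gives > 10000 nM, also a limit.

Compound 2 therefore stands at the limit, where both values shown sit (the limit of > 10000 nM in this assay, at which 2 of the 2 values shown sit). Going by the values given here, the only measured step, a step that the two limits leave unreadable from compound 1 to compound 2, cannot be read. Compound 3 `COc1cccc(NC(=O)c2nccc3ccccc23)c1` differs from compound 2 by methoxy in place of chloro on an aromatic carbon. No readable step bears on this change, so no size or direction beyond the scatter can be expected in this assay. Compound 3 is expected at 15000 nM, between 5000 nM and 50000 nM. The expected step is a step that the limit leaves unreadable from compound 2 to compound 3.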

Compound 3, concentration for 50% growth inhibition: > 10000 nM
Compound 3 ended at the assay's limit; the forecaster's own chance of this, stated with the estimate: 80%; the middle value is on the limit's open side.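

The steps among compound 1, compound 2 and compound 3 cannot be read, because all three sit at one limit: the limit of > 10000 nM in this assay, at which 3 of the 3 values shown sit.
In this assay the compounds shown leave open how strongly each inhibits growth, and whether methoxy, chloro and trifluoromethyl differ at all.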